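A few compounds are considered here, and "the series" means these few. Any claim that something is new, unique, unknown or untested is made for them only; others in the source may bear on it.

Measured compounds:
- compound 1, `CCCCCC(=O)c1ccc(OCCCN2CCN(C(=O)OCC(C)C)CC2)cc1` — 3720 nM
- compound 2, `CCCCCC(=O)c1ccc(OCCCN2CCN(C(=O)N3CCOCC3)CC2)cc1` — 17800 nM
- compound 3, `CCOC(=O)N1CCN(CCCOc2ccc(C(=O)CC(C)C)cc2)CC1` — 69200 nM

These three share a core and were tested in an assay on isolated protein for binding affinity to histamine H2 receptor (Homo sapiens); a lower number here means a stronger inhibitor, a higher number a weaker inhibitor. Compound 3 gives the highest number of the three, so it is the weakest binder in this set; compound 2 is its nearest neighbour, and compound 1 is the furthest. For the measured compounds named here, the only single-place step among the measured compounds is a 4.8-fold higher number from compound 1 to compound 2 (0.68 log units; beyond the scatter), which concerns the carbonyl on the piperazine, not the ketone.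

Compound 4, `CCOC(=O)N1CCN(CCCOc2ccc(C(=O)c3cccc(C)c3)cc2)CC1`, is not yet measured. It differs from compound 3 in one place: 3-methylphenyl in place of isobutyl on a carbonyl carbon. Going by the values given here, no measured pair shows this kind of change, so nothing here says how an aromatic ring in that position behaves. Compound 1 and compound 3 differ in two places at once, so their gap cannot be tied to either one.

Among the compounds with values here, with no bearing step, compound 4 is expected to give a value in this assay near that of compound 3, with a wide band: the estimate is 40000 nM (range 8000 nM to 200000 nM), meaning an expected step of a 1.7-fold lower number from compound 3 to compound 4 (0.24 log units; within the scatter).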

Compound 4, inhibition constant: 3720 nM
The estimate for compound 4 lay 11-fold (1.03 log units) above the measured number; measured number below the stated range.
By their numbers in this assay, from the lowest: compounds 1 and 4 (each within the scatter of the next); then compound 2; then compound 3.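

Before this result, no measured pair showed what the group on this carbonyl carbon does to binding. In this assay, 3-methylphenyl in place of isobutyl gives a 19-fold lower number from compound 3 to compound 4 (1.27 log units; beyond the scatter) and so marks this position as highly sensitive to the group it carries. This is one pair, so it shows the effect of this exchange and no general rule for aromatic rings here, and nothing available explains the size of the step.

Going by these compounds, it remains open whether the ring alone accounts for the step or the methyl also contributes, which plain phenyl would help to separate, and whether cyclohexyl, a ring without aromatic character, would behave alike. On these data alone, it is also open whether the same exchange would have a similar effect alongside isobutoxy or morpholin-4-yl on the other carbonyl.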